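A methoxy step on a phenyl ether

A few compounds are considered here, and "the series" means these few. Any claim that something is new, unique, unknown or untested is made for them only; others in the source may bear on it.

- compound 1 `NC1=NC2(CCSCC2)N(OCCCOc2ccc(Cl)c(Cl)c2)C(N)=N1`: 140 nM
- compound 2 `NC1=NC2(CCOCC2)N(OCCCOc2ccccc2)C(N)=N1`: 2460 nM

In a functional assay on HL-60 cells (Homo sapiens) for antiproliferative activity, read by MTT assay, with a stated time of 72 h (on this read-out lower numbers stand for stronger inhibition and higher numbers for weaker inhibition), compound 2 gives 2460 nM, the higher of the two numbers, while compound 1 gives 140 nM, a gap beyond the scatter. Going by the values given here, the two compounds differ in more than one place, so they give no measured step for a single change.

Compound 3 `COc1ccc(OCCCON2C(N)=NC(N)=NC23CCOCC3)cc1` changes compound 2 in one place: methoxy in place of hydrogen on an aromatic carbon. Methoxy stands in place of hydrogen on an aromatic carbon, turning phenyl into 4-methoxyphenyl.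

Among the compounds with values here, with no direct precedent, no step beyond the scatter is expected in this assay, with only a slight lean towards a lower number. The estimated step is a 1.4-fold lower number from compound 2 to compound 3 (0.16 log units; within the scatter). Compound 3 is expected at 1700 nM, with an estimated range of 500 nM to 5500 nM.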

Compound 3, half-maximal inhibitory concentration: 1670 nM
The estimate for compound 3 lay 1.0-fold (0.01 log units) above the measured number, and the stated range covers the measured number.
By their numbers in this assay, from the lowest: compound 1; then compounds 3 and 2 (each within the scatter of the next).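

In this assay, going by these compounds alone, the first step for a single change is a 1.5-fold lower number from compound 2 to compound 3 (0.17 log units; within the scatter) and it lies within the scatter. Methoxy on this aromatic carbon, para to a large group, is therefore accepted in this assay: turning phenyl into 4-methoxyphenyl leaves the number where the scatter alone could place it. Nothing at hand explains why the step has this size.

The compounds shown leave open whether this position is as accepting of other groups, such as an amine, a carboxylic acid or a single chlorine atom on the same carbon. The much lower number of compound 1 also remains unassigned, since it differs from compound 2 in more than one place and the separate contributions of those differences cannot be read.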